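The compounds below may be only part of what the source reports. "The series", "measured", "known", "first", "only" and "open" are said of these compounds alone.

Compound 3, `Cc1cc(C)cc(S(=O)(=O)c2c(C(N)=O)[nH]c3ccc(Cl)cc23)c1`, carries a plain primary amide on the shared core. In a toxicity assay on MT4 cells (Homo sapiens) for cytotoxicity, read by MTT assay, with a stated time of 7 days (on this read-out lower numbers stand for higher toxicity in this test and higher numbers for lower toxicity in this test), compound 3 gives 5520 nM, the lowest of the two numbers recorded, so among the compounds measured here it is the one that harms the cells at the lowest concentration. The two other measured compounds carry larger groups on that same amide nitrogen. Compound 1, `Cc1cc(C)cc(S(=O)(=O)c2c(C(=O)NC3CC4(CCN(Cc5n[nH]c(=O)n5C)CC4)C3)[nH]c3ccc(Cl)cc23)c1`, gives 178000 nM in this assay, a number far above that of compound 3. Compound 2, `Cc1cc(C)cc(S(=O)(=O)c2c(C(=O)NC3CC4(C3)CN(C(=O)OC(C)(C)C)C4)[nH]c3ccc(Cl)cc23)c1`, reaches only the limit of this assay, > 224000 nM, which is a boundary of the measurement and not a number; as noted in the limit of > 224000 nM in this assay, at which 1 of the 3 values shown sits, one of the three values recorded sits at this limit.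

Compound 4, `Cc1cc(C)cc(S(=O)(=O)c2c(C(=O)NC3CC4(CNC4)C3)[nH]c3ccc(Cl)cc23)c1`, is not yet measured. It differs from compound 3 by a group of 7 heavy atoms (6 carbon, 1 nitrogen; one four-membered non-aromatic ring of carbon only, one four-membered non-aromatic ring with 1 hetero atom) in place of a hydrogen atom, on an amide-type nitrogen. Among the measured compounds shown here, no step between measured compounds is recorded for this exact change, so the expectation rests on the two measured analogues with substituted amides. Compound 1 gives 178000 nM in this assay. Compound 2 sits at the limit of this assay. On that basis the step from compound 3 to compound 4 is expected to be large and upward, toward lower toxicity, as a 16-fold higher number from compound 3 to compound 4 (1.21 log units; beyond the scatter). Compound 4 is therefore estimated to give 90000 nM in this assay, within a range of 25000 nM to 224000 nM.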

Compound 4, half-maximal cytotoxic concentration: 28600 nM
Estimate against measurement, compound 4: 3.1-fold (0.50 log units) above, within the range that was stated.
By their numbers in this assay, from the lowest: compound 3; then compound 4; then compound 1. At a limit, above all of these: compound 2.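

Among the compounds shown here, replacing the amide hydrogen with this group of two four-membered rings is the first single change at this position that can be read in this assay, and it gives a 5.2-fold higher number from compound 3 to compound 4 (0.71 log units; beyond the scatter), so substitution on this amide-type nitrogen moves the number upward, toward lower toxicity in this test. A second single change, hydrogen in place of tert-butoxycarbonyl on an amine nitrogen in a ring, gives an at least 7.8-fold lower number from compound 2 to compound 4 (0.89 log units; beyond the scatter), which shows that the substituent on that ring nitrogen also matters in this test and that the free ring amine goes with the lower number of the pair. Compound 2 stands at a limit of the assay, which is not a number: the limit of > 224000 nM in this assay, at which 1 of the 4 values shown sits.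

As far as these compounds go, whether the upward step needs the two four-membered rings, or whether a plain methyl group or a longer alkyl chain on the same amide-type nitrogen would move the number as well, stays open. From the compounds shown here alone, it is also open how an acetyl or a methyl group on the ring nitrogen would compare with the free amine and with tert-butoxycarbonyl.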